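A Fourth Acetoxy Group on a Compound at the Limit

The source may report more compounds than this note shows. Statements on the series, on what has been measured and on what is new or still open speak of the compounds shown alone.

Compound 1 `COc1cc(-c2cc3cccc(C)c3oc2=O)cc(OC)c1OC`: > 60000 nM
Compound 2 `CC(=O)Oc1ccc(-c2cc3ccc(OC(C)=O)c(OC(C)=O)c3oc2=O)cc1`: > 100000 nM
Compound 3 `CC(=O)Oc1ccc(-c2cc3cccc(OC(C)=O)c3oc2=O)cc1OC(C)=O`: > 100000 nM

All three were tested in an assay on CHO cells for displacement of a labelled ligand from adenosine receptor A1 (Homo sapiens), read by radioligand binding; on this read-out lower numbers stand for stronger inhibition and higher numbers for weaker inhibition. None of the three gave a number. Compound 1 sits at the limit of > 60000 nM in this assay, at which 1 of the 3 values shown sits, which is a limit of the assay and not a measured value. Compound 2 sits at the limit of > 100000 nM in this assay, at which 2 of the 3 values shown sit, again a limit rather than a number. Compound 3 stands at that same limit, so it shows no measurable binding on this assay. No pair among these three differs in just one place, so no single step can be read from them.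

Compound 4 `CC(=O)Oc1ccc(-c2cc3ccc(OC(C)=O)c(OC(C)=O)c3oc2=O)cc1OC(C)=O` has not been measured. Compared with compound 3 the change is acetoxy in place of hydrogen on an aromatic carbon. With compound 3 already at the limit of > 100000 nM in this assay, at which 2 of the 3 values shown sit, a step of this kind is not expected to move the result beyond the scatter in either direction. The step from compound 3 to compound 4 is estimated as a step that the limit leaves unreadable from compound 3 to compound 4. Compound 4 is therefore expected to give about 150000 nM, within a range of 50000 nM to 600000 nM, and most probably to be reported once more as a limit.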

Compound 4, inhibition constant: > 100000 nM
Compound 4: only a limit was reported; the forecaster's own chance of this, stated with the estimate: 90%; the middle value does not contradict the limit.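

Compound 4 gives > 100000 nM, which is a limit of the assay and not a number. Compound 2 and compound 3 also stand at limits, and the steps from each of them to compound 4 cannot be read. The compounds shown leave open whether acetoxy in place of hydrogen on an aromatic carbon changes binding at all: none of the four gives a number.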